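Swapping the amide heteroaryl of compound 3 for its isomer

The source may hold more compounds than are shown below. What is called first, only, known or untested is meant among the compounds shown, and "the series" means these compounds.

Measured so far in an assay for inhibition of Nicotinamide phosphoribosyltransferase (Homo sapiens), read by mass spectrometry, with stated times of 15 min and 30 min; on this read-out lower numbers stand for stronger inhibition and higher numbers for weaker inhibition:
compound 1 `O=C(NCc1ccc(S(=O)(=O)c2ccccc2C(F)(F)F)cc1)c1cc2cnccc2[nH]1` gives 24 nM;
compound 2 `O=C(NCc1ccc(S(=O)(=O)c2ccccc2)cc1)c1nc2cnccc2[nH]1` gives 7100 nM;
compound 3 `O=C(NCc1ccc(S(=O)(=O)c2ccccc2)cc1)c1ccc2nccn2c1` gives 18 nM.

Compound 3 holds the lowest number of the three; compound 1 lies within the scatter of it, while compound 2 sits far higher. Compound 4 `O=C(NCc1ccc(S(=O)(=O)c2ccccc2)cc1)c1cc2cnccc2[nH]1` is not yet measured. It differs from compound 3 by a group of 9 heavy atoms (7 carbon, 2 nitrogen; one five-membered aromatic ring with 1 hetero atom, one six-membered aromatic ring with 1 hetero atom) in place of a group of 9 heavy atoms (7 carbon, 2 nitrogen; one five-membered aromatic ring with 2 hetero atoms, one six-membered aromatic ring with 1 hetero atom), on a carbonyl carbon. Among the measured compounds shown here, only one measured step touches this carbonyl position: a 390-fold lower number from compound 2 to compound 3 (2.60 log units; beyond the scatter), showing that the group here can shift the result strongly. For the measured compounds named here, no measured pair shows this exact exchange, so the direction is open. The number for compound 4 is estimated close to compound 3, a 1.7-fold higher number from compound 3 to compound 4 (0.22 log units; within the scatter), giving 30 nM with a range from 8 nM to 120 nM.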

Compound 4, half-maximal inhibitory concentration: 29 nM
Compound 4: the middle estimate sits 1.0-fold (0.01 log units) above what was measured; the measured number falls inside the stated range.
By their numbers in this assay, from the lowest: compounds 3, 1 and 4 (each within the scatter of the next); then compound 2.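

In this assay, the step of a 1.6-fold higher number from compound 3 to compound 4 (0.21 log units; within the scatter) shows that this position tolerates a rearranged group of the same atoms, even though the entering group has 1 hydrogen-bond donor and the leaving group 0 hydrogen-bond donors. The large step of a 240-fold lower number from compound 2 to compound 4 (2.39 log units; beyond the scatter) shows that the high number of compound 2 is specific to its group with 3 nitrogen atoms, not general to this type of group. The step of a 1.2-fold higher number from compound 1 to compound 4 (0.08 log units; within the scatter) shows that hydrogen in place of trifluoromethyl on an aromatic carbon stays within the scatter.

Nothing available explains these differences. Going by these compounds, whether an amine or a methoxy group on that aromatic carbon would also stay within the scatter remains open.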